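Benzyl amide in place of chloroanilide on a chromone acrylamide

The source may hold more compounds than are shown below. What is called first, only, known or untested is meant among the compounds shown, and "the series" means these compounds.

Measured compounds:
compound 1 `O=C(/C=C/c1coc2cc(O)ccc2c1=O)NCc1ccccc1`, 63000 nM
compound 2 `COc1ccc2c(=O)c(/C=C/C(=O)Nc3ccccc3Cl)coc2c1`, 23000 nM
compound 3 `COc1ccc(CNC(=O)/C=C/c2coc3cc(OC)ccc3c2=O)cc1`, 15700 nM

In a functional assay (QGY7701 cells, Homo sapiens) for inhibition, read by MTT assay, with a stated time of 48 h (on this read-out lower numbers stand for stronger inhibition and higher numbers for weaker inhibition), compound 2 gives 23000 nM, the second highest of the three numbers; compound 3 lies nearest, compound 1 furthest. Compound 4 `COc1ccc2c(=O)c(/C=C/C(=O)NCc3ccc(C)cc3)coc2c1` has not been measured; it differs from compound 2 by 4-methylbenzyl in place of 2-chlorophenyl on an amide-type nitrogen. Going by the values given here, the only step that bears on this is the one with 4-methoxybenzyl in place of 2-chlorophenyl on an amide-type nitrogen, a 1.5-fold lower number from compound 2 to compound 3 (0.17 log units; within the scatter), which stayed within the scatter. A change of the same kind is therefore expected to give at most a small move, a 1.3-fold lower number from compound 2 to compound 4 (0.11 log units; within the scatter), toward a lower number. Compound 4 is accordingly estimated at 18000 nM, within 8000 nM to 40000 nM.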

Compound 4, half-maximal inhibitory concentration: 10200 nM
For compound 4 the middle estimate is 1.8-fold (0.25 log units) above the measured one; the measured number falls inside the stated range.
By their numbers in this assay, from the lowest: compounds 4, 3 and 2 (each within the scatter of the next, the first and the last beyond it); then compound 1.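

In this assay, going by these compounds alone, 4-methylbenzyl in place of 2-chlorophenyl on the amide-type nitrogen gives the first step at this position that passes beyond the scatter (a 2.3-fold lower number from compound 2 to compound 4 (0.35 log units; beyond the scatter)). Methyl in place of methoxy on an aromatic carbon stays within the scatter (a 1.5-fold lower number from compound 3 to compound 4 (0.19 log units; within the scatter)), so these two groups are not told apart here. Nothing measured here explains the step from compound 2 to compound 4.

The compounds shown leave open how a carboxylic acid or an amine in place of the methyl would read. They also leave open what a longer chain in place of the benzyl methylene would do.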